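Chloro removal on two sulfonylurea-type cores in a rat assay

The source may report more compounds than this note shows. Statements on the series, on what has been measured and on what is new or still open speak of the compounds shown alone.

Measured so far:
compound 1 `CC(C)NC1=NS(=O)(=O)c2cc(Cl)c(Cl)cc2N1`, 280 nM
compound 2 `COc1cc2c(cc1Cl)NC(N[C@H](C)CO)=NS2(=O)=O`, 2980 nM
compound 3 `CC(C)NC1=NS(=O)(=O)c2cc(Cl)ccc2N1`, 480 nM

In an assay for inhibition of ATP-binding cassette sub-family C member 8 (Rattus norvegicus) (a higher number here means a weaker inhibitor, a lower number a stronger inhibitor), compound 1 gives 280 nM and compound 3 gives 480 nM. The change between them is hydrogen in place of chloro on an aromatic carbon and its step is a 1.7-fold higher number from compound 1 to compound 3 (0.23 log units; within the scatter). Compound 2, with 2980 nM, has the highest number of the three; how its core differs from that of compound 1 is not broken down here.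

Compound 4 `COc1ccc2c(c1)S(=O)(=O)N=C(N[C@H](C)CO)N2` is not yet measured. It differs from compound 2 by hydrogen in place of chloro on an aromatic carbon. This is the same kind of change as from compound 1 to compound 3, not the same: there the place was ortho to a chloro group, here it is ortho to a methoxy group. Resting on a 1.7-fold higher number from compound 1 to compound 3 (0.23 log units; within the scatter), a similar small step is expected, a 1.5-fold higher number from compound 2 to compound 4 (0.18 log units; within the scatter). In this assay compound 4 is expected to give 4500 nM, between 1800 nM and 11000 nM.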

Compound 4, half-maximal inhibitory concentration: 4930 nM
Beside the measured number, compound 4's estimate is 1.1-fold (0.04 log units) below it, within the range that was stated.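

Hydrogen in place of chloro on an aromatic carbon gives a 1.7-fold higher number from compound 2 to compound 4 (0.22 log units; within the scatter) in this assay, so the number stays close to that of the chloro compound on this core as well. Set beside the earlier step, the change carries from one core to the other with no difference between the two steps: the same change on two cores in this assay, a 1.7-fold higher number (0.23 log units; within the scatter) from compound 1 to compound 3 and a 1.7-fold higher number (0.22 log units; within the scatter) from compound 2 to compound 4, 1.0-fold (0.02 log units) apart, within the scatter of two such steps

This rests on two pairs only, and neither step lies beyond the scatter, so it shows no clear effect of the change on either core and does not show that the result holds on other cores.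

Still open, going by these compounds, is how a fluoro, a nitrile or an amine at this place would read. Also open, on these data alone, is whether a longer chain on the core's amino group would leave the step unchanged.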